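This account rests on a few compounds, and the source may have more. Where it says the series, first, only, none or still open, it means among the compounds named here.

Three compounds were tested in a functional assay on T47D cells (Homo sapiens) for antiproliferative activity, read by MTT assay, with a stated time of 48 h; on this read-out lower numbers stand for stronger inhibition and higher numbers for weaker inhibition. Compound 1, `COc1ccc(/C=N/c2c(C#N)ncn2-c2ccc(F)cc2)cc1`, gives 19400 nM. Compound 2, `CC(C)c1ccc(/C=N/c2c(C#N)ncn2-c2ccc(F)cc2)cc1`, gives > 25000 nM, which is a limit of the assay and not a number. That value is the limit of > 25000 nM in this assay, at which 1 of the 3 values shown sits. The change between them, (isopropyl in place of methoxy on an aromatic carbon), produced an at least 1.2-fold higher number from compound 1 to compound 2 (0.11 log units; that floor lies within the scatter).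

Compound 3, `COc1ccc(C2N=C(C(N)=O)c3ncn(-c4ccc(F)cc4)c3N2)cc1`, is built on a different core, and the difference between the two cores is not broken down here. In this assay compound 3 gives 5870 nM, the lowest number among the measured compounds.

Compound 4, `CC(C)c1ccc(C2N=C(C(N)=O)c3ncn(-c4ccc(F)cc4)c3N2)cc1`, is not yet measured. It differs from compound 3 by isopropyl in place of methoxy on an aromatic carbon, the same change seen from compound 1 to compound 2, on the same kind of place. Because that earlier change gave an at least 1.2-fold higher number from compound 1 to compound 2 (0.11 log units; that floor lies within the scatter), compound 4 is expected to give a somewhat higher number than compound 3, estimated as a 1.5-fold higher number from compound 3 to compound 4 (0.19 log units; within the scatter). On that basis compound 4 is expected to reach about 9000 nM in this assay, most likely between 4000 nM and 20000 nM.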

Compound 4, half-maximal inhibitory concentration: 5350 nM
Beside the measured number, compound 4's estimate is 1.7-fold (0.23 log units) above it; the measured number falls inside the stated range.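

In this assay, isopropyl in place of methoxy on the aromatic carbon gives a 1.1-fold lower number from compound 3 to compound 4 (0.04 log units; within the scatter), so on this core the swap produces no readable change. Two cores cannot show whether this change carries over from one core to the other in the same way, and they cannot show that it fails to carry over either: the same change on two cores in this assay, an at least 1.2-fold higher number (0.11 log units; that floor lies within the scatter) from compound 1 to compound 2 and a 1.1-fold lower number (0.04 log units; within the scatter) from compound 3 to compound 4; the limit leaves it open whether they differ Compound 2 gives > 25000 nM, which is a limit of the assay and not a number.

The compounds shown leave open how other groups on the same aromatic carbon, such as an amine, a carboxylic acid or a longer chain, would read on either core. Going by these compounds, it also remains open whether the result seen with compound 3 and compound 4 would hold on a third core, or whether a swap to one of those other groups would give a step beyond the scatter.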